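The source may hold more compounds than are shown below. What is called first, only, known or untested is meant among the compounds shown, and "the series" means these compounds.

Measured so far:
- Compound 1 `Clc1cccc(-c2cc(-c3ccc(Cl)o3)cc(-c3cccs3)n2)c1`: 42%
- Compound 2 `Cc1ccc(-c2cc(-c3ccc(Cl)o3)cc(-c3ccsc3)n2)o1`: 9.1%

Within the data shown here, in an assay on isolated protein for inhibition of DNA topoisomerase 1 (Homo sapiens), tested at 100 uM (on this read-out higher numbers stand for a stronger effect at the one concentration tested and lower numbers for a weaker effect), compound 2 stands lowest of the two numbers known; its nearest neighbour is compound 1, whose value lies higher by a gap that is beyond the usual scatter. Among the measured compounds shown here, no single-change step between measured compounds is available, so the two values can only be set side by side.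

Compound 3 `Clc1ccc(-c2cc(-c3ccsc3)nc(-c3ccccc3Cl)c2)o1` has not yet been measured in this assay. It differs from compound 2 by 2-chlorophenyl in place of 5-methylfuran-2-yl on an aromatic carbon, the exchange sitting on an aromatic carbon of the shared core, next to the ring nitrogen.

For the measured compounds named here, with no measured step to lean on, the expectation rests on the range the two known values span. Compound 3 is estimated to move upward from compound 2, an expected step of a number 18.9 percentage points higher from compound 2 to compound 3 (beyond the scatter) in this assay, because compound 1 reaches 42% while compound 2 gives 9.1%. For compound 3 the estimate in this assay is 28%, with a range from 8% to 50%.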

Compound 3, a percentage reported as inhibition, at one concentration (the size of the read-out at that concentration, not a potency): 0%
Beside the measured number, compound 3's estimate is 28 percentage points above it, and the stated range ends above it.
By their numbers in this assay, from the lowest: compounds 3 and 2 (each within the scatter of the next); then compound 1.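

In this assay, among these compounds, the step of a number 9.1 percentage points lower from compound 2 to compound 3 (within the scatter) is the first single-change comparison, and it concerns the aromatic carbon next to the ring nitrogen. At that place, 2-chlorophenyl in place of 5-methylfuran-2-yl swaps a five-membered aromatic ring carrying oxygen for a six-membered aromatic ring of carbon only with a chlorine, yet the read-out does not separate beyond the usual scatter, so this exchange shows no measurable effect on top of the 5-chlorofuran-2-yl and thiophen-3-yl groups that compound 2 and compound 3 share. Compound 1 differs from each of them in more than one place, so its value cannot be assigned to this position, and nothing measured here accounts for the outcome of the exchange.

The compounds shown leave open what makes compound 1 different, since neither its thiophen-2-yl group nor its chlorophenyl group has been varied on its own. They also leave open how this place next to the ring nitrogen would respond to a group of another kind, such as an amine or a carboxylic acid.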